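This account rests on a few compounds, and the source may have more. Where it says the series, first, only, none or still open, it means among the compounds named here.

Compound 1 `Oc1cccc(-c2cc(-c3ccccc3)cc(-c3cccs3)n2)c1`: 18900 nM in a functional assay on DU-145 cells (Homo sapiens) for cytotoxicity, read by ELISA, with a stated time of 2 days; on this read-out higher numbers stand for weaker inhibition and lower numbers for stronger inhibition
Compound 2 `Oc1cccc(-c2cc(-c3ccccc3)nc(-c3ccccc3)c2)c1`: 17900 nM in this assay

Compound 2 has the lowest of the two numbers in this assay, yet compound 1 sits within the scatter of it, so the two cannot be told apart. No step between measured compounds that differ in one place is shown. Compound 3 `Oc1cccc(-c2cc(-c3ccccc3)nc(-c3ccsc3)c2)c1` differs from compound 2 as follows: thiophen-3-yl in place of phenyl on an aromatic carbon. Since compound 1 gives 18900 nM, close to compound 2, a step of no size beyond the scatter is expected in this assay, namely a 1.0-fold higher number from compound 2 to compound 3 (0.00 log units; within the scatter). Compound 3 is therefore estimated at 18000 nM, in the range 7000 nM to 45000 nM.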

Compound 3, half-maximal inhibitory concentration: 11700 nM
Compound 3: middle estimate off by 1.5-fold (0.19 log units), on the high side, and the stated range covers the measured number.
By their numbers in this assay, from the lowest: compounds 3, 2 and 1 (each within the scatter of the next).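

In this assay, going by these compounds alone, this is the first one-place comparison at this position: thiophen-3-yl in place of phenyl on the aromatic carbon next to the ring nitrogen gives a 1.5-fold lower number from compound 2 to compound 3 (0.18 log units; within the scatter) and so stays within the scatter. Here, the five-membered sulfur-containing ring and the six-membered carbon ring cannot be told apart on this read-out. Nothing measured here bears on why this is so.

As far as these compounds go, it remains open whether a non-aromatic group at this position, such as an amine or a carboxylic acid, would shift the number beyond the scatter. Also open, from the compounds shown here alone, is whether replacing the hydroxyl of the 3-hydroxyphenyl group with a methoxy group would do so.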